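Removing a methyl group from three inactive compounds

A few compounds are considered here, and "the series" means these few. Any claim that something is new, unique, unknown or untested is made for them only; others in the source may bear on it.

Compound 1 `COc1cc2nccc(O)c2c(O)c1OC` and compound 2 `COc1cc2nccc(O)c2c(OC)c1OC` share one core and differ in a single place. In a functional assay on L1210 cells (Mus musculus) for antiproliferative activity (a higher number here means a weaker inhibitor, a lower number a stronger inhibitor), compound 1 gives only a limit, > 40000 nM. In this assay compound 2 likewise gives a limit, > 40000 nM. The change between them is hydrogen in place of methyl on an oxygen on an aromatic ring, and it makes a step that the two limits leave unreadable from compound 2 to compound 1. Compound 3 `COc1cc(C(F)(F)F)cc2nccc(O)c12` carries a trifluoromethyl group; how its core differs from that of compound 2 is not broken down here. In this assay compound 3 gives a limit, > 40000 nM. Compound 4 `Oc1ccnc2cc(C(F)(F)F)cc(O)c12` has not been measured and differs from compound 3 by hydrogen in place of methyl on an oxygen on an aromatic ring, the same change as between compound 2 and compound 1. The step is expected to be a step that the limit leaves unreadable from compound 3 to compound 4, resting on (the limit of > 40000 nM in this assay, at which 3 of the 3 values shown sit). Compound 4 is expected to give about 60000 nM, most likely somewhere from 20000 nM to 200000 nM.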

Compound 4, half-maximal inhibitory concentration: > 40000 nM
Compound 4: a limit, no number (the forecaster's own chance of this, stated with the estimate: 85%); the middle value lies beyond the limit too.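

Compound 3 and compound 4 both give only limits in this assay, so no step can be read between them. Whether methoxy to hydroxy changes antiproliferative activity at all stays open, as none of the compounds shown gives an actual number.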